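The source may hold more compounds than are shown below. What is called first, only, known or untested is meant among the compounds shown, and "the series" means these compounds.

Measured so far:
- Compound 1 `Cn1c(COc2cccc(C(=O)O)c2)nc2ccc(Oc3ccc(Cl)cn3)cc21` in an ADME assay for permeability, using PAMPA, with a stated time of 4 h (on this read-out higher numbers stand for higher permeability and lower numbers for lower permeability), gives 16.2 10^-6 cm/s.
- Compound 2 `Cn1c(COc2cccc(C(=O)O)c2)nc2ccc(Oc3ncccc3Cl)cc21` in this assay gives 8.1 10^-6 cm/s.

Among the compounds with values here, of these two numbers, compound 2 holds the lower one, but the only step between them, a 2.0-fold lower number from compound 1 to compound 2 (0.30 log units; within the scatter), lies within the scatter, so the two compounds cannot be told apart on this read-out. Compound 3 `Cc1cccnc1Oc1ccc2nc(COc3cccc(C(=O)O)c3)n(C)c2c1` differs from compound 2 in one place: methyl in place of chloro on an aromatic carbon. Within the data shown here, no measured step exchanges chloro for methyl. Among the measured compounds shown here, the single measured step, a 2.0-fold lower number from compound 1 to compound 2 (0.30 log units; within the scatter), moves the chloro from one aromatic carbon of the pyridine to another and stays within the scatter, which gives no ground for a shift in either direction. With nothing in the measured pair pointing to a change beyond the scatter, the number for compound 3 is expected to stay near that of compound 2. The expected step is a 1.0-fold higher number from compound 2 to compound 3 (0.02 log units; within the scatter). Compound 3 is therefore estimated at 8.5 10^-6 cm/s in this assay, with a range from 4 10^-6 cm/s to 18 10^-6 cm/s.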

Compound 3, apparent permeability: 6 10^-6 cm/s
Estimate against measurement, compound 3: 1.4-fold (0.15 log units) above, and the stated range covers the measured number.
By their numbers in this assay, from the lowest: compounds 3, 2 and 1 (each within the scatter of the next, the first and the last beyond it).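

In this assay, the exchange of chloro for methyl on this aromatic carbon, two atoms from the ring nitrogen, now has a direct reading: a 1.4-fold lower number from compound 2 to compound 3 (0.13 log units; within the scatter), so the two groups cannot be told apart at this place. With 3-methylpyridin-2-yl in place of 5-chloropyridin-2-yl on the oxygen, the series gains its first step beyond the scatter, a 2.7-fold lower number from compound 1 to compound 3 (0.43 log units; beyond the scatter), though this step is modest and compound 2 lies within the scatter of both compound 1 and compound 3. No measurement at hand bears on the reason for either step.

As far as these compounds go, it remains open whether a group other than chloro or methyl at this place, such as an amine, a methoxy or a nitrile, would carry the number beyond the scatter from compound 2. Also open, from the compounds shown here alone, is whether methyl at the place held by chloro in compound 1 would read like that chloro, and so whether the step to compound 3 follows the group, its place, or both.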